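Trimethoxyphenyl oxadiazoline series: dichlorophenyl placement

The compounds below may be only part of what the source reports. "The series", "measured", "known", "first", "only" and "open" are said of these compounds alone.

Measured so far:
compound 1 `COc1cc(C2=NN(C(C)=O)C(c3c(Cl)cccc3Cl)O2)cc(OC)c1OC` — 5.1%
compound 2 `COc1cc(C2=NN(C(C)=O)C(c3cc(OC)c(OC)c(OC)c3)O2)cc(OC)c1OC` — -1.8%

In a functional assay on PC-3 cells (Homo sapiens) for antiproliferative activity, read by MTT assay, tested at 1 uM (a lower number here means a weaker effect, a higher number a stronger effect of the compound at the concentration tested), compound 1 gives the highest of the two numbers, but compound 2 lies within the scatter of it, so nothing separates them. Both read-outs sit near zero. Compound 3 `COc1cc(C2=NN(C(C)=O)C(c3ccc(Cl)c(Cl)c3)O2)cc(OC)c1OC` is yet to be measured. It differs from compound 1 by 3,4-dichlorophenyl in place of 2,6-dichlorophenyl on a saturated ring carbon. For the measured compounds named here, with no measured step between two compounds differing in one place, there is nothing to scale a prediction from; the expected step of a number 0.1 percentage points lower from compound 1 to compound 3 (within the scatter) is none beyond the scatter. Compound 3 is expected to give 5%, with a range from -8% to 18%.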

Compound 3, a percentage reported as inhibition, at one concentration (the size of the read-out at that concentration, not a potency): 28.1%
Compound 3: middle estimate off by 23.1 percentage points, on the low side, outside the stated range (above it).
By their numbers in this assay, from the lowest: compounds 2 and 1 (each within the scatter of the next); then compound 3.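

In this assay, 3,4-dichlorophenyl in place of 2,6-dichlorophenyl on the saturated ring carbon gives a number 23 percentage points higher from compound 1 to compound 3 (beyond the scatter). The two compounds hold the same atoms, so the placement of the two chlorines on this phenyl alone separates them, and this position responds to that change. Nothing available explains the step.

Open, as far as these compounds go, is whether a fluorine or a nitrile in place of the chlorines keeps this read-out. Also open, from the compounds shown here alone, is whether the step holds with a propionyl group in place of the acetyl group.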